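Swapping a methyl for a chloro at the same place

The compounds below may be only part of what the source reports. "The series", "measured", "known", "first", "only" and "open" are said of these compounds alone.

Of the compounds shown here, three sharing one core have been tested in a functional assay on cells (T-cell, Mus musculus, strain BALB/c) for inhibition, read by MTT assay, with stated times of 24 h and 72 h; a lower number here means a stronger inhibitor, a higher number a weaker inhibitor. Compound 1 `COc1cc(-c2nnc(SCc3ccc([N+](=O)[O-])cc3)o2)ccc1O` gives 14200 nM, compound 2 `COc1cc(-c2nnc(SCc3ccc(C)cc3)o2)ccc1O` gives 6210 nM, and compound 3 `COc1cc(-c2nnc(SCc3ccccc3[N+](=O)[O-])o2)ccc1O` gives 9600 nM. Compound 2 sits at the low end of these three numbers: compound 1 lies beyond the scatter, while compound 3 cannot be told apart from compound 2. Among the measured compounds shown here, the only step measured between neighbours is a 2.3-fold lower number from compound 1 to compound 2 (0.36 log units; beyond the scatter), a modest change.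

Compound 4 `COc1cc(-c2nnc(SCc3ccc(Cl)cc3)o2)ccc1O` differs from compound 2 by chloro in place of methyl on an aromatic carbon. For the measured compounds named here, no measured step exchanges methyl for chloro, so the only guidance is that replacing a group on this same carbon, para to a large group, moved this assay by a 2.3-fold lower number from compound 1 to compound 2 (0.36 log units; beyond the scatter), and that the other variation seen, compound 3, stays within the scatter of compound 2. A step of no more than the scatter is therefore expected from compound 2 to compound 4, a 1.0-fold lower number from compound 2 to compound 4 (0.01 log units; within the scatter), in no firm direction. Compound 4 is estimated at 6000 nM, with a range from 3000 nM to 12000 nM.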

Compound 4, half-maximal inhibitory concentration: 11100 nM
Compound 4: middle estimate off by 1.9-fold (0.27 log units), on the low side; the measured number falls inside the stated range.
By their numbers in this assay, from the lowest: compounds 2, 3, 4 and 1 (each within the scatter of the next, the first and the last beyond it).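

In this assay, putting chloro in place of methyl on this aromatic carbon gives a 1.8-fold higher number from compound 2 to compound 4 (0.25 log units; within the scatter) and so leaves the two groups indistinguishable here. Chloro is equally indistinguishable from nitro on the same carbon, with a 1.3-fold lower number from compound 1 to compound 4 (0.11 log units; within the scatter) as the step. Compound 4 therefore separates from neither compound 2 nor compound 1, although a 2.3-fold lower number from compound 1 to compound 2 (0.36 log units; beyond the scatter) remains the one step among these three compounds that lies beyond the scatter, and no available evidence accounts for these numbers.

Going by these compounds, three groups on one carbon span only a narrow set of values, so it stays open how much this position can change the result. An amine, a carboxylic acid or a longer chain on this carbon might give a clearer answer.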